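The source may report more compounds than this note shows. Statements on the series, on what has been measured and on what is new or still open speak of the compounds shown alone.

Three compounds share one core and differ only in the group on the six-membered aromatic ring with one nitrogen. In a functional assay for antagonist activity at transient receptor potential cation channel subfamily V member 1 (Rattus norvegicus) (a higher number here means a weaker inhibitor, a lower number a stronger inhibitor), compound 1 `CC(C)(C)c1ccc(NC(=O)c2ccc(-c3ncccc3F)cc2)cc1` gives 1 nM, compound 2 `CCCNc1cccnc1-c1ccc(C(=O)Nc2ccc(C(C)(C)C)cc2)cc1` gives 37 nM, and compound 3 `CCS(=O)(=O)Nc1cccnc1-c1ccc(C(=O)Nc2ccc(C(C)(C)C)cc2)cc1` gives 4 nM. Compound 3 thus stands second highest of the three, and its nearest neighbour is compound 1 through the step of a 4.0-fold higher number from compound 1 to compound 3 (0.60 log units; beyond the scatter), while the step of a 9.3-fold lower number from compound 2 to compound 3 (0.97 log units; beyond the scatter) separates it further from compound 2. Compound 4 `CC(C)(C)c1ccc(NC(=O)c2ccc(-c3ncccc3-c3ncc[nH]3)cc2)cc1` continues the series with the change (1H-imidazol-2-yl in place of (ethylsulfonyl)amino on an aromatic carbon). Among the measured compounds shown here, the steps that bear on this position are a 37-fold higher number from compound 1 to compound 2 (1.57 log units; beyond the scatter) and a 4.0-fold higher number from compound 1 to compound 3 (0.60 log units; beyond the scatter): both replacements of fluoro raised the number, one strongly and one modestly, and the amine-bearing groups differ from the entering aromatic ring in what is counted. Compound 4 is therefore expected to land near compound 3 or somewhat higher, an estimated step of a 2.5-fold higher number from compound 3 to compound 4 (0.40 log units; beyond the scatter) in this assay. The estimate for compound 4 is 10 nM, with a range from 2 nM to 50 nM.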

Compound 4, half-maximal inhibitory concentration: 694 nM
Compound 4: middle estimate off by 69-fold (1.84 log units), on the low side; the whole stated range lies below it.
By their numbers in this assay, from the lowest: compound 1; then compound 3; then compound 2; then compound 4.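

In this assay, the 1H-imidazol-2-yl group is the least well accepted of the four groups shown on this aromatic carbon, with a 170-fold higher number from compound 3 to compound 4 (2.24 log units; beyond the scatter), a 19-fold higher number from compound 2 to compound 4 (1.27 log units; beyond the scatter) and a 690-fold higher number from compound 1 to compound 4 (2.84 log units; beyond the scatter). The earlier compounds shown here showed only that two nitrogen-linked chains raised the number over fluoro by different amounts; compound 4 adds a group with a five-membered aromatic ring and gives a far larger rise. The (ethylsulfonyl)amino and 1H-imidazol-2-yl groups each count one hydrogen-bond donor, so that shared count did not keep the number low, and nothing measured here accounts for the rise.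

The compounds shown leave open whether the high number goes with any aromatic ring at this place or with the 1H-imidazol-2-yl group alone. A phenyl or a thiazolyl group at the same carbon would separate these two readings.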